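A few compounds are considered here, and "the series" means these few. Any claim that something is new, unique, unknown or untested is made for them only; others in the source may bear on it.

Measured in a functional assay on NCI-H358 cells (Homo sapiens) for cytotoxicity, read by sulforhodamine B assay; a higher number here means that more compound is needed for the effect, a lower number that less compound is needed:
- compound 1 `CCCCCCCCCCCCC/C=C/[C@@H](O)[C@H](CO)n1cc(CCC)nn1`: 15700 nM
- compound 2 `CCCCCCCCCCCCC/C=C/[C@@H](O)[C@H](CO)n1cc(CCCCCCCCCCCCC)nn1`: > 50000 nM (a limit of the assay)
- compound 3 `CCCCCCCCCCCCC/C=C/[C@@H](O)[C@H](CO)n1cc(CCCCCC)nn1`: 12800 nM

For the measured compounds named here, compound 3 gives 12800 nM, and a 1.2-fold lower number from compound 1 to compound 3 (0.09 log units; within the scatter) places it level with the only other true number in this assay. Compound 2 gives no number, only a limit: the limit of > 50000 nM in this assay, at which 1 of the 3 values shown sits.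

Compound 4 `CCCCCCCCCCCCC/C=C/[C@@H](O)[C@H](CO)n1cc(CCCC)nn1` is reached by hydrogen in place of ethyl on a saturated chain carbon, four bonds along the chain from an aromatic carbon, which replaces ethyl with hydrogen on a saturated chain carbon, four bonds along the chain from an aromatic carbon. Its chain is shorter than that of compound 3 and longer than that of compound 1, so the closest evidence is a 1.2-fold lower number from compound 1 to compound 3 (0.09 log units; within the scatter). The much larger change in chain length, an at least 3.9-fold lower number from compound 2 to compound 3 (0.59 log units; beyond the scatter), goes beyond the scatter, but it is tied to a limit and involves a far longer chain, so it bears on this small change only weakly. No shift beyond the scatter is therefore expected. The expected step is a 1.1-fold higher number from compound 3 to compound 4 (0.04 log units; within the scatter). The estimated value for compound 4 is 14000 nM, with an expected range of 8000 nM to 24000 nM.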

Compound 4, half-maximal effective concentration: 13600 nM
Estimate against measurement, compound 4: 1.0-fold (0.01 log units) above, within the range that was stated.
By their numbers in this assay, from the lowest: compounds 3, 4 and 1 (each within the scatter of the next). At a limit, above all of these: compound 2.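

Replacing ethyl with hydrogen at this position, on a saturated chain carbon, four bonds along the chain from an aromatic carbon, leaves the result in this assay essentially unmoved: a 1.1-fold higher number from compound 3 to compound 4 (0.03 log units; within the scatter), and a 1.2-fold lower number from compound 1 to compound 4 (0.06 log units; within the scatter). Compounds 1, 3 and 4 therefore sit at one level, and these shorter chains show no order among themselves. Only the far longer chain of compound 2 stands apart, an at least 3.6-fold lower number from compound 2 to compound 4 (0.56 log units; beyond the scatter), and that step rests on a limit rather than a number: the limit of > 50000 nM in this assay, at which 1 of the 4 values shown sits.

Where along the chain length between compound 3 and compound 2 the number begins to climb remains open, and a decyl chain at this position would help to locate it. Also open, going by these compounds, is how this assay would respond to a chain ending in an amine or a carboxylic acid.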